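Solubility notes on a sulfoxide amide series

The source may report more compounds than this note shows. Statements on the series, on what has been measured and on what is new or still open speak of the compounds shown alone.

Measured so far in an ADME assay for solubility; a lower number here means a less soluble compound, a higher number a more soluble compound:
- compound 1, `CCCCCCCCCC[S+]([O-])CCC(=O)NC(CO)(CO)CO`, gives > 10000 ug/mL, a limit of the assay.
- compound 2, `CCCCCCCCCCCC[S+]([O-])CCC(=O)NC(CO)(CO)CO`, gives > 6000 ug/mL, also a limit of the assay.
- compound 3, `O=C(CC[S+]([O-])CCC(F)(F)C(F)(F)C(F)(F)C(F)(F)C(F)(F)C(F)(F)F)NC(CO)(CO)CO`, gives 1200 ug/mL.

For the measured compounds named here, compound 3 is thus the only compound of the three with a read number in this assay; the other two values are limits, marked by the limit of > 10000 ug/mL in this assay, at which 1 of the 3 values shown sits, for compound 1 and the limit of > 6000 ug/mL in this assay, at which 1 of the 3 values shown sits, for compound 2. Going by the values given here, the one measured step, a step that the two limits leave unreadable from compound 1 to compound 2, is left unreadable by those two limits and concerns a hydrocarbon chain, so no measured step bears directly on the change considered here.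

Compound 4, `O=C(CC[S+]([O-])CCC(F)(F)C(F)(F)C(F)(F)C(F)(F)C(F)(F)C(F)(F)C(F)(F)C(F)(F)F)NC(CO)(CO)CO`, differs from compound 3 by 1,1,2,2,2-pentafluoroethyl in place of fluoro on a saturated chain carbon bound to two fluorine atoms and a saturated chain carbon. Among the compounds with values here, nothing among the measured steps gives a size for lengthening this chain, so the expectation rests on the read value of compound 3 alone and on the direction the chain extension suggests. The step from compound 3 to compound 4 is estimated as a drop in this assay, a 4.0-fold lower number from compound 3 to compound 4 (0.60 log units; beyond the scatter), beyond the scatter. Compound 4 is therefore expected to give about 300 ug/mL, in the range 80 ug/mL to 1000 ug/mL.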

Compound 4, solubility: 25 ug/mL
Compound 4: middle estimate off by 12-fold (1.08 log units), on the high side, and the stated range ends above it.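

In this assay, 1,1,2,2,2-pentafluoroethyl in place of fluoro on a saturated chain carbon bound to two fluorine atoms and a saturated chain carbon gives a 48-fold lower number from compound 3 to compound 4 (1.68 log units; beyond the scatter), so a change at this position on the fluorinated chain now has a readable size, and that size is large. For the compounds shown here, this is the only readable step, as the step on the hydrocarbon chain cannot be read and offers no size to set against it. The values shown give a size for the change but no measured property that would account for it.

From the compounds shown here alone, it remains open whether the drop continues with a still longer fluorinated chain or flattens out, since a single step gives a size for this one change but no trend along the chain. Going by these compounds, it also remains open how a chain of the same kind would stand in this assay if it carried a carboxylic acid or an amine, or if it held a mixed stretch of hydrocarbon and fluorinated carbons.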